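Hydroxy removal on the shared core: expected cytotoxicity

A few compounds are considered here, and "the series" means these few. Any claim that something is new, unique, unknown or untested is made for them only; others in the source may bear on it.

Compound 1 `COc1ccc2[nH]c(-c3ccc[se]3)cc(=O)c2c1OC` reports only a limit of > 100000 nM in an ADME assay on Detroit 551 cells (Homo sapiens) for cytotoxicity, read by MTT assay, with a stated time of 48 h; on this read-out higher numbers stand for weaker inhibition and lower numbers for stronger inhibition. Compound 2 `COc1ccc2[nH]c(-c3ccc[se]3)cc(=O)c2c1O` gives 100000 nM in this assay, the only number shown. The step of a number no higher from compound 1 to compound 2 (the limit leaves the size open) cannot be sized because of the limit of > 100000 nM in this assay, at which 1 of the 2 values shown sits. Compound 3 `COc1ccc2[nH]c(-c3ccc[se]3)cc(=O)c2c1` differs from compound 2 by hydrogen in place of hydroxy on an aromatic carbon. For the measured compounds named here, the one measured step touches an oxygen on the same ring but its size is not readable, so no shift beyond the scatter is expected in this assay. The step of no change at the digits printed from compound 2 to compound 3 (within the scatter) is therefore estimated small. Compound 3 is expected near 100000 nM, with a range from 30000 nM to 300000 nM.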

Compound 3, half-maximal inhibitory concentration: > 10000 nM
Compound 3: a limit, no number (the forecaster's own chance of this, stated with the estimate: 50%); the middle value is on the limit's open side.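

In this assay, for the compounds shown here, compound 3 gives only a limit, > 10000 nM, so no new step linking compound 3 to compound 1 or compound 2 can be read. Going by these compounds, whether hydrogen in place of hydroxy shifts the value in this assay stays open.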